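This account rests on a few compounds, and the source may have more. Where it says the series, first, only, none or still open, it means among the compounds named here.

Measured so far in a functional assay on MCF7 cells (Homo sapiens) for inhibition, read by sulforhodamine B assay, with a stated time of 48 h; a lower number here means a stronger inhibitor, a higher number a weaker inhibitor:
- Compound 1 `C=CCC(O)(c1ccc(OC)c(OC)c1OC)c1cccc2ccccc12`: > 20000 nM, a limit
- Compound 2 `CCOC(=O)/C=C/CO/N=C(/c1ccc(OC)c(OC)c1OC)c1cccc2ccccc12`: > 20000 nM, a limit

Compound 1 stands at a limit and not at a number, and compound 2 shares it: the limit of > 20000 nM in this assay, at which 2 of the 2 values shown sit. Compound 3 `CCOC(=O)C(C)C(O)(c1ccc(OC)c(OC)c1OC)c1cccc2ccccc12` has 1-(ethoxycarbonyl)ethyl in place of allyl on a saturated chain carbon bound to two aromatic carbons and an oxygen on a saturated carbon. Among the compounds with values here, no measured step yet shows the effect of such a change in this assay. The expected outcome is a number no higher from compound 1 to compound 3 (the limit leaves the size open), with no change beyond the scatter. For compound 3 the estimate is 20000 nM, with an expected range of 8000 nM to 50000 nM.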

Compound 3, half-maximal inhibitory concentration: > 20000 nM
Compound 3: only a limit was reported; the forecaster's own chance of this, stated with the estimate: 65%; the middle value lies on the limit itself.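

No step can be read from compound 1 to compound 3: both stand at a limit in this assay. The compounds shown leave open whether 1-(ethoxycarbonyl)ethyl in place of allyl changes inhibition at all, and what number any of them would give.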